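Diaryl ethers: nitrile against dimethylamino, all at the limit

A few compounds are considered here, and "the series" means these few. Any claim that something is new, unique, unknown or untested is made for them only; others in the source may bear on it.

Compound 1 `COC(=O)c1cccc(Oc2ccc(C#N)cc2)c1` and compound 2 `COC(=O)c1cccc(Oc2ccc(N(C)C)cc2)c1` share one core; compound 3 `COc1cccc(OC)c1Oc1ccc(C#N)cc1` and compound 4 `COc1cccc(OC)c1Oc1ccc(N(C)C)cc1` share another, and the difference between the two cores is not broken down here. In a functional assay on HL-60 cells (Homo sapiens) for antiproliferative activity (a higher number here means a weaker inhibitor, a lower number a stronger inhibitor), compound 1 gives only a limit of the assay, > 20000 nM. Compound 2 likewise gives only a limit, > 20000 nM. Compound 3 also gives only a limit, > 20000 nM. The change from compound 1 to compound 2 is dimethylamino in place of cyano on an aromatic carbon, and its step is a step that the two limits leave unreadable from compound 1 to compound 2. The change from compound 3 to compound 4 is dimethylamino in place of cyano on an aromatic carbon, the same change at the same kind of place. Because (the limit of > 20000 nM in this assay, at which 3 of the 3 values shown sit), the step is expected to remain unreadable in this assay; the expected step is a step that the limit leaves unreadable from compound 3 to compound 4. Compound 4 is expected at 30000 nM, most probably reported again only as a limit.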

Compound 4, half-maximal inhibitory concentration: 11400 nM
The estimate for compound 4 lay 2.6-fold (0.42 log units) above the measured number; the measured number falls inside the stated range.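

In this assay, dimethylamino in place of cyano on the core of compound 3 gives an at least 1.7-fold lower number from compound 3 to compound 4 (0.24 log units; that floor lies within the scatter), a floor that lies within the usual scatter, so no firm gain can be claimed on this core. The same change on the core of compound 1 cannot be read, because both compounds there sit at a limit of the assay: the limit of > 20000 nM in this assay, at which 3 of the 4 values shown sit. These compounds therefore neither support nor contradict carrying the change from one core to the other.

As far as these compounds go, it remains open how far the number for compound 4 would move with a primary amine or a carboxylic acid on that aromatic carbon. From the compounds shown here alone, the difference between the two cores also remains open.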